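A Fluorophenyl Piperazine Amide Against a Silent Series

The source may report more compounds than this note shows. Statements on the series, on what has been measured and on what is new or still open speak of the compounds shown alone.

Compound 1, `CN1CCN(C(=O)CNC(=O)c2ccc(S(C)(=O)=O)c([N+](=O)[O-])c2)CC1`, was measured in an assay on isolated protein for inhibition of thyroid hormone receptor alpha (Homo sapiens), read by fluorescence polarization; a higher number here means a weaker inhibitor, a lower number a stronger inhibitor. In this assay compound 1 gives > 60000 nM, which is a limit of the assay and not a number. Two compounds share its core and differ only at the amide nitrogen. Compound 2, `CN(Cc1ccccc1)C(=O)CNC(=O)c1ccc(S(C)(=O)=O)c([N+](=O)[O-])c1`, gives > 60000 nM in this assay, again a limit. Compound 3, `CC(C)N(C(=O)CNC(=O)c1ccc(S(C)(=O)=O)c([N+](=O)[O-])c1)C(C)C`, gives > 60000 nM in this assay, also a limit. The steps among them are therefore unreadable: a step that the two limits leave unreadable from compound 1 to compound 2, a step that the two limits leave unreadable from compound 1 to compound 3 and a step that the two limits leave unreadable from compound 2 to compound 3, because of the limit of > 60000 nM in this assay, at which 3 of the 3 values shown sit.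

Compound 4, `CS(=O)(=O)c1ccc(C(=O)NCC(=O)N2CCN(c3ccccc3F)CC2)cc1[N+](=O)[O-]`, has not yet been measured. It differs from compound 1 by 2-fluorophenyl in place of methyl on an amine nitrogen in a ring. Going by the values given here, none of the measured steps touches this position, and none of them yields a readable size, so there is no basis for expecting a change in this assay beyond the scatter in either direction. The three limits shown all sit at the same value, and the change in compound 4 is larger than any of those three variations.

Compound 4 is therefore expected to give 60000 nM in this assay, within 15000 nM to 200000 nM, which corresponds to an expected step of a number no higher from compound 1 to compound 4 (the limit leaves the size open).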

Compound 4, half-maximal inhibitory concentration: > 60000 nM
Compound 4 ended at the assay's limit; the forecaster's own chance of this, stated with the estimate: 75%; the middle value sits exactly at the limit.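

In this assay compound 4 gives > 60000 nM, which is a limit of the assay and not a number. No size can be read for the change from compound 1 to compound 4, because both compounds end at the same limit: the limit of > 60000 nM in this assay, at which 4 of the 4 values shown sit.

The compounds shown leave open whether any change on this shared core gives a measurable value in this assay.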